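This account rests on a few compounds, and the source may have more. Where it says the series, first, only, none or still open, it means among the compounds named here.

The study concerns a series built on one shared core, tested in an assay on HEK293 cells for positive allosteric modulation of metabotropic glutamate receptor 5 (Homo sapiens), read by FLIPR, with a stated time of 1 h; on this read-out lower numbers stand for an effect already at smaller amounts and higher numbers for an effect only at larger amounts of compound. Compound 1 `O=C(C1CC1)N1CCc2nc(C#Cc3ccccc3)sc2C1` is the plain member of the set. In this assay compound 1 gives > 10000 nM, which is a limit of the assay and not a number. Two relatives were measured: compound 3 `O=C(C1CCC(F)(F)CC1)N1CCc2nc(C#Cc3ccccc3)sc2C1` gives 70 nM in this assay, and compound 2 `O=C(C1CC(F)(F)C1)N1CCc2nc(C#Cc3cccc(F)c3)sc2C1` differs from compound 1 in two places. In this assay compound 2 gives 2.5 nM. Among the compounds with values here, the single clean step, an at least 140-fold lower number from compound 1 to compound 3 (2.15 log units; beyond the scatter), shows how much the ring attached to the carbonyl matters; compound 1 is the one sitting at the limit of > 10000 nM in this assay, at which 1 of the 3 values shown sits. Compound 4 `O=S(=O)(C1CC1)N1CCc2nc(C#Cc3ccccc3)sc2C1` poses a different question: cyclopropylsulfonyl in place of cyclopropylcarbonyl on an amine nitrogen in a ring. Within the data shown here, no measured step bears on this exchange, since the only step known alters the ring and not the linking group, and compound 4 keeps the cyclopropyl of compound 1. Compound 4 is therefore expected to remain weak, with a step that the limit leaves unreadable from compound 1 to compound 4 expected to stay within the scatter. Compound 4 is estimated at 15000 nM, in a range from 2000 nM to 100000 nM.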

Compound 4, half-maximal effective concentration: > 10000 nM
Compound 4: only a limit was reported; the forecaster's own chance of this, stated with the estimate: 70%; the middle value does not contradict the limit.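

Within the data shown here, compound 1 and compound 4 both sit at a limit of this assay, so no step between them can be read: the limit of > 10000 nM in this assay, at which 2 of the 4 values shown sit. The compounds shown leave open how cyclopropylsulfonyl compares with cyclopropylcarbonyl wherever the read-out gives a number rather than a limit.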